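The compounds below may be only part of what the source reports. "The series", "measured", "known", "first", "only" and "open" are said of these compounds alone.

Working notes on the oxime-ether series.

Three compounds have numbers in a functional assay on SK-OV-3 cells (Homo sapiens) for cytotoxicity, read by MTT assay, with a stated time of 2 days; a lower number here means a stronger inhibitor, a higher number a weaker inhibitor. Compound 1 `CC(=O)Nc1ccc2c(c1)/C(=N\O)C(c1c[nH]c3ccc(NC(C)=O)cc13)=N2` gives 21300 nM. Compound 2 `Cc1ccc(CO/N=C2/C(c3c[nH]c4ccccc34)=Nc3ccccc32)cc1` gives 32400 nM, the highest of the three numbers, though its gap to compound 1 lies within the scatter and no order between those two can be claimed. Compound 3 `FC(F)(F)c1ccc(CO/N=C2/C(c3c[nH]c4ccc(Br)cc34)=Nc3ccc(Br)cc32)cc1` gives 10200 nM, a lower number than compound 2 by a margin beyond the scatter; compound 3 differs from compound 2 in more than one place, so nothing is read from that pair about any single change.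

Compound 4 `Fc1ccc(CO/N=C2/C(c3c[nH]c4ccccc34)=Nc3ccccc32)c(Cl)c1` is not yet measured in this assay. It differs from compound 2 in one place: 2-chloro-4-fluorophenyl in place of 4-methylphenyl on a saturated chain carbon bound to an oxygen on an unsaturated carbon. Going by the values given here, no measured pair shows this change on its own, so there is no step to draw on. The expectation is for no step beyond the scatter, with at most a slight move toward a lower number, and the estimated step is a 1.3-fold lower number from compound 2 to compound 4 (0.11 log units; within the scatter). Compound 4 is therefore estimated at 25000 nM, with a range from 9000 nM to 65000 nM.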

Compound 4, half-maximal inhibitory concentration: 37600 nM
Beside the measured number, compound 4's estimate is 1.5-fold (0.18 log units) below it; low and high end bracket the measured number.
By their numbers in this assay, from the lowest: compound 3; then compounds 1, 2 and 4 (each within the scatter of the next).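

In this assay, going by these compounds alone, the change from 4-methylbenzyl to 2-chloro-4-fluorobenzyl gives the only single-place comparison so far, a 1.2-fold higher number from compound 2 to compound 4 (0.06 log units; within the scatter) and this step lies within the scatter. At this position, on a saturated chain carbon bound to an oxygen on an unsaturated carbon, the assay therefore does not tell the 2-chloro-4-fluorophenyl group from the 4-methylphenyl group, and the added halogens show no readable effect on this core. No measurement at hand bears on why the two groups read alike.

Open, going by these compounds, is whether an amine or a carboxylic acid on this ring, or a longer chain in place of the benzyl link, would move the number beyond the scatter. Also open, on these data alone, is whether the same change reads alike on the core of compound 3.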